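Phenyl for pyridin-2-yl in a limit-bound cytotoxicity series

The source may report more compounds than this note shows. Statements on the series, on what has been measured and on what is new or still open speak of the compounds shown alone.

Working notes on four compounds built on closely related cores. Compound 1 `C=C1C[C@]23C[C@@]1(O)CC[C@H]2c1ccc(O)c(C)c1[C@@H]3Cn1cc(-c2ccccn2)nn1` and compound 2 `C=C1C[C@]23C[C@@]1(O)CC[C@@H]2c1cccc(C)c1[C@@H]3Cn1cc(-c2ccccn2)nn1` differ in more than one place; the difference between the two cores is not broken down here. Compound 3 `C=C1C[C@]23C[C@@]1(O)CC[C@H]2c1ccc(O)c(C)c1[C@@H]3Cn1cc(-c2ccccc2)nn1` comes from compound 1 by one change, (phenyl in place of pyridin-2-yl on an aromatic carbon). Compound 4 `C=C1C[C@]23C[C@@]1(O)CC[C@@H]2c1cccc(C)c1[C@@H]3Cn1cc(-c2ccccc2)nn1` comes from compound 2 by the same change, (phenyl in place of pyridin-2-yl on an aromatic carbon), at a place described in the same words, so the two steps are taken as the same change made twice.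

In a functional assay on MCF7 cells (Homo sapiens) for cytotoxicity, read by MTT assay, with a stated time of 4 days (a higher number here means a weaker inhibitor, a lower number a stronger inhibitor), compound 1 gives > 20000 nM, which is a limit of the assay and not a number. In this assay compound 2 gives > 20000 nM, again only a limit. In this assay compound 3 gives > 20000 nM, also a limit. The measured step from compound 1 to compound 3 is therefore a step that the two limits leave unreadable from compound 1 to compound 3, and its size cannot be read because of the limit of > 20000 nM in this assay, at which 3 of the 3 values shown sit.

Among the measured compounds shown here, for compound 4 the only guide is that compound 2 and the measured pair both sit at the limit; the step from compound 2 to compound 4 is expected to be a step that the limit leaves unreadable from compound 2 to compound 4, without a readable size, because of the limit of > 20000 nM in this assay, at which 3 of the 3 values shown sit. Compound 4 is accordingly expected in this assay to come out near 30000 nM, within 15000 nM to 100000 nM, most likely reported only as a limit.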

Compound 4, half-maximal inhibitory concentration: > 20000 nM
Compound 4 gave a limit, no number; the forecaster's own chance of this, stated with the estimate: 90%; the middle value is on the limit's open side.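

In this assay compound 4 gives > 20000 nM, which is a limit of the assay and not a number. No new step can be read from compound 2 to compound 4, and the phenyl for pyridin-2-yl change stays without a size: the limit of > 20000 nM in this assay, at which 4 of the 4 values shown sit.

The compounds shown leave open whether phenyl and pyridin-2-yl differ at all in this assay, on either core.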